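The compounds below may be only part of what the source reports. "The series", "measured", "known", "first", "only" and "open" are said of these compounds alone.

Two compounds share one core and differ only in the aryl group sitting on the carbonyl carbon of an amide. Compound 1 `O=C(Nc1cccc(-c2oc3cc(-c4ccc(F)cc4)ccc3c(=O)c2O)c1)c1ccccc1F` is the smaller of the two, and in a functional assay on A549 cells (Homo sapiens) for antiproliferative activity, read by CCK-8 assay, with a stated time of 72 h (a lower number here means a stronger inhibitor, a higher number a weaker inhibitor), compound 1 gives 4410 nM. Compound 2 `O=C(Nc1cccc(-c2oc3cc(-c4ccc(F)cc4)ccc3c(=O)c2O)c1)c1ccc(F)cc1F` adds fluoro in place of hydrogen on an aromatic carbon, and in this assay compound 2 gives 20500 nM. That single change produced a 4.6-fold higher number from compound 1 to compound 2 (0.67 log units; beyond the scatter), so compound 2 holds the highest of the two numbers and is the weaker inhibitor of the pair.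

Compound 3 `CCCc1ccc(C(=O)Nc2cccc(-c3oc4cc(-c5ccc(F)cc5)ccc4c(=O)c3O)c2)cc1` has not yet been measured. Relative to compound 2 the change is 4-propylphenyl in place of 2,4-difluorophenyl on a carbonyl carbon. For the measured compounds named here, the only measured step that bears on this is a 4.6-fold higher number from compound 1 to compound 2 (0.67 log units; beyond the scatter), in which one fluoro entering raised the number modestly. Going by the values given here, compound 3 removes both fluorines and brings in a propyl chain, whose effect has no measured precedent here. Compound 3 is expected to show a 5.9-fold lower number from compound 2 to compound 3 (0.77 log units; beyond the scatter). For compound 3 the estimate in this assay is 3500 nM, with a range from 900 nM to 14000 nM.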

Compound 3, half-maximal inhibitory concentration: 47600 nM
The estimate for compound 3 lay 14-fold (1.13 log units) below the measured number; the measured number lies above the stated range.
By their numbers in this assay, from the lowest: compound 1; then compound 2; then compound 3.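

Putting 4-propylphenyl in place of 2,4-difluorophenyl on the carbonyl carbon gives a 2.3-fold higher number from compound 2 to compound 3 (0.37 log units; beyond the scatter) in this assay, so taking both fluorines away and adding a propyl chain does not bring back the activity lost with the second fluorine. Against the single-fluorine group the same 4-propylphenyl gives an 11-fold higher number from compound 1 to compound 3 (1.03 log units; beyond the scatter), the largest step among these compounds, which places compound 3 as the weakest of the three and compound 1 as the strongest, and shows that this position on the amide can move the number substantially while the shared core stays fixed. No separate measurement accompanies these numbers, so the reason for this order remains unknown.

This swap changes two things at once, so the share of the fluorines' loss and the share of the propyl chain's arrival cannot be told apart; a plain phenyl or a methyl-bearing phenyl on the same carbonyl carbon would help separate them. As far as these compounds go, whether an amine or a carboxylic acid on that ring could bring the number below that of compound 1 also remains open.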